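The source may hold more compounds than are shown below. What is called first, only, known or untested is meant among the compounds shown, and "the series" means these compounds.

In an ADME assay on MT4 cells (Homo sapiens) for cytotoxicity, read by MTT assay (on this read-out lower numbers stand for higher toxicity in this test and higher numbers for lower toxicity in this test), compound 2 `CCCCCNC(=O)C1C(=O)N(O)C(=O)c2ccccc21` gives 130000 nM and compound 1 `CCCCCCCCCNC(=O)C1C(=O)N(O)C(=O)c2ccccc21` gives 88500 nM, which lie within the scatter of each other, while compound 3 `CCN(CC)C(=O)C1C(=O)N(O)C(=O)c2ccccc21` gives a lower 28000 nM. Compound 4 `CC(C)(C)NC(=O)C1C(=O)N(O)C(=O)c2ccccc21` has tert-butyl in place of pentyl on an amide-type nitrogen. Within the data shown here, two measured steps bear on this change. Hydrogen in place of butyl gave a 1.5-fold higher number from compound 1 to compound 2 (0.17 log units; within the scatter), whereas diethylamino in place of pentylamino gave a 4.6-fold lower number from compound 2 to compound 3 (0.67 log units; beyond the scatter). Compound 4 keeps the amide hydrogen, so the first of these is taken as the closer guide, and no change beyond the scatter is expected in this assay. The expected step is a 1.4-fold lower number from compound 2 to compound 4 (0.14 log units; within the scatter). Compound 4 is estimated at 95000 nM, with an expected range of 40000 nM to 190000 nM.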

Compound 4, half-maximal cytotoxic concentration: 142000 nM
Estimate against measurement, compound 4: 1.5-fold (0.17 log units) below; low and high end bracket the measured number.
By their numbers in this assay, from the lowest: compound 3; then compounds 1, 2 and 4 (each within the scatter of the next).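

Among these compounds, with tert-butyl in place of pentyl on an amide-type nitrogen, this assay shows a 1.1-fold higher number from compound 2 to compound 4 (0.04 log units; within the scatter), so at this position a branched group reads like the straight chains of the earlier compounds. (tert-Butyl)amino in place of diethylamino on a carbonyl carbon gives a 5.1-fold higher number from compound 3 to compound 4 (0.71 log units; beyond the scatter), which leaves compound 3, the only one of the four without the amide hydrogen, standing apart from compound 4. No measurement shown gives a reason for either step. As far as these compounds go, whether a phenyl ring, an amine or a carboxylic acid on this nitrogen's substituent would stay in the same range remains open.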